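The compounds below may be only part of what the source reports. "The series", "measured", "known", "first", "only" and "open" are said of these compounds alone.

In an assay on isolated protein for inhibition of Rho-associated protein kinase 1 (Homo sapiens), read by scintillation counting, radiometric assay and 33P incorporation, with a stated time of 40 min, in the presence of a further agent that is not named here (a higher number here means a weaker inhibitor, a lower number a stronger inhibitor), compound 3 `O=C(COc1ccc2c(=O)ccoc2c1)Nc1cccc(NC(=O)c2ccccc2)c1` gives 120 nM, the lowest of the three numbers recorded; compound 2 `COc1ccc(OCC(=O)Nc2cccc(NC(=O)c3ccc(N(C)C)cc3)c2)cc1F` gives 1820 nM and compound 1 `COc1cc(OCC(=O)Nc2cccc(NC(=O)c3ccc(N(C)C)cc3)c2)ccc1C=O` gives 3740 nM in this assay. Among the compounds with values here, the one step measured, a 2.1-fold lower number from compound 1 to compound 2 (0.31 log units; beyond the scatter), concerns the ether side of the shared core and not the benzamide end. Compound 4 `O=C(COc1ccc2c(=O)ccoc2c1)Nc1cccc(NC(=O)c2ccc(F)cc2)c1` differs from compound 3 by fluoro in place of hydrogen on an aromatic carbon. Within the data shown here, no measured step bears on this change, so the account can only expect a step within the usual scatter, in no set direction. Compound 4 is therefore estimated at 120 nM in this assay, with a range from 50 nM to 300 nM, meaning an expected step of no change at the digits printed from compound 3 to compound 4 (within the scatter).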

Compound 4, half-maximal inhibitory concentration: 129 nM
The estimate for compound 4 lay 1.1-fold (0.03 log units) below the measured number; the measured number falls inside the stated range.
By their numbers in this assay, from the lowest: compounds 3 and 4 (each within the scatter of the next); then compound 2; then compound 1.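

Within the data shown here, the benzamide end, untouched by the only earlier step, now has a measured step of its own: in this assay, fluoro in place of hydrogen on the aromatic carbon para to a large group gives a 1.1-fold higher number from compound 3 to compound 4 (0.03 log units; within the scatter) and leaves compound 3 and compound 4 indistinguishable. At this position, then, the phenyl and 4-fluorophenyl forms read alike on this ether side. Nothing measured here offers a reason for this result. Still open, on these data alone, is how an amine or a carboxylic acid on that same aromatic carbon would read. Also open, as far as these compounds go, is whether fluoro there would read alike with the ether sides of compound 1 and compound 2.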